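Aryl amide variation and growth inhibition in one series

This account rests on a few compounds, and the source may have more. Where it says the series, first, only, none or still open, it means among the compounds named here.

Three measured compounds share a core and differ only in the aryl group on the amide-type nitrogen: compound 1 `CN(C)C(=O)c1cc2cnc(Nc3ccc(NC(=O)C4(C(=O)Nc5ccc(Cl)cc5)CC4)cc3)nc2n1C1CCCC1`, compound 2 `CN(C)C(=O)c1cc2cnc(Nc3ccc(NC(=O)C4(C(=O)Nc5ccccc5F)CC4)cc3)nc2n1C1CCCC1` and compound 3 `CN(C)C(=O)c1cc2cnc(Nc3ccc(NC(=O)C4(C(=O)Nc5cccc(Cl)c5)CC4)cc3)nc2n1C1CCCC1`. In a functional assay on OVCAR-5 cells (Homo sapiens) for inhibition, read by CCK-8 assay, with a stated time of 72 h, tested at 10 uM (on this read-out higher numbers stand for more inhibition of growth at the one concentration tested and lower numbers for less inhibition of growth), compound 1 gives 85.3%, compound 2 gives 82.6% and compound 3 gives 88.1%. Compound 1 sits among the other two on these numbers, and every step stays within the scatter: a number 2.7 percentage points lower from compound 1 to compound 2 (within the scatter), a number 2.8 percentage points higher from compound 1 to compound 3 (within the scatter) and a number 5.5 percentage points higher from compound 2 to compound 3 (within the scatter). Compound 4 `CN(C)C(=O)c1cc2cnc(Nc3ccc(NC(=O)C4(C(=O)Nc5ccc(Cl)c(C(F)(F)F)c5)CC4)cc3)nc2n1C1CCCC1` has not been measured; it differs from compound 1 by trifluoromethyl in place of hydrogen on an aromatic carbon. Among the compounds with values here, no measured step adds a group to the aryl ring, yet the aryl variations among compounds 1, 2 and 3 all stay within the scatter, so no step beyond the scatter is expected for a number 0.7 percentage points higher from compound 1 to compound 4 (within the scatter). Compound 4 is estimated at 86%, range 76% to 94%.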

Compound 4, percent growth inhibition at one concentration: 48%
For compound 4 the middle estimate is 38 percentage points above the measured one, and the stated range ends above it.
By their numbers in this assay, from the lowest: compound 4; then compounds 2, 1 and 3 (each within the scatter of the next).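

Notes on the series: in this assay, trifluoromethyl on the aromatic carbon ortho to a chloro group gives a large loss (a number 37.3 percentage points lower from compound 1 to compound 4 (beyond the scatter)), so this aryl ring does not tolerate every change, as the earlier swaps alone might have suggested. The low number holds against the other aryl groups as well (a number 40.1 percentage points lower from compound 3 to compound 4 (beyond the scatter); a number 34.6 percentage points lower from compound 2 to compound 4 (beyond the scatter)). Nothing available explains this loss.
The compounds shown leave open whether it follows trifluoromethyl itself or its pairing with the chloro group. A methyl or methoxy group on the same carbon would help separate these readings.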